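Trading one ether side chain on compound 1

This account rests on a few compounds, and the source may have more. Where it says the series, first, only, none or still open, it means among the compounds named here.

Compound 1 `CC(C)(C)OC[C@@H](O)C(=O)N1[C@H](C(=O)NCc2cc(Cl)ccc2-n2cnnn2)C[C@@H]2C[C@@H]21`: 21 mL.min-1.g-1
Compound 2 `COC(C)(C)[C@@H](O)C(=O)N1N=CC[C@H]1C(=O)NCc1cc(Cl)ccc1-n1cnnn1`: < 12 mL.min-1.g-1

Both compounds were tested in an ADME assay on liver for metabolic stability, with Liver microsome (Homo sapiens) as the target, read by LC-MS, using microsomes; a lower number here means slower removal, a higher number faster removal of the compound. Among the compounds with values here, compound 1 gives 21 mL.min-1.g-1, the only exact number available so far. Compound 2 gives < 12 mL.min-1.g-1, which is a limit of the assay and not a number.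

Compound 3 `COC(C)(C)[C@@H](O)C(=O)N1[C@H](C(=O)NCc2cc(Cl)ccc2-n2cnnn2)C[C@@H]2C[C@@H]21` keeps the core of compound 1 and changes one side chain: 1-methoxy-1-methylethyl in place of (tert-butoxy)methyl on a saturated chain carbon bound to a carbonyl carbon and an oxygen on a saturated carbon. The swap places 1-methoxy-1-methylethyl in place of (tert-butoxy)methyl. Within the data shown here, no measured pair of compounds isolates this change, so any forecast is tentative. A small fall in this assay is expected, possibly no larger than the usual scatter between repeat measurements. The expected step is a 1.4-fold lower number from compound 1 to compound 3 (0.15 log units; within the scatter). Compound 3 is estimated at 15 mL.min-1.g-1, with an expected range from 8 mL.min-1.g-1 to 28 mL.min-1.g-1.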

Compound 3, intrinsic clearance in microsomes: 40 mL.min-1.g-1
Compound 3: middle estimate off by 2.7-fold (0.43 log units), on the low side, outside the stated range (above it).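

Within the data shown here, this is the first pair of compounds that isolates a single change at this position, since the earlier compounds offered no step to read. In this assay, placing 1-methoxy-1-methylethyl in place of (tert-butoxy)methyl on this saturated chain carbon gives a 1.9-fold higher number from compound 1 to compound 3 (0.28 log units; within the scatter). On the core of compound 1, these two side chains therefore cannot be told apart in this read-out, and the pair gives no firm sign that this change matters.

Compound 2 carries the same 1-methoxy-1-methylethyl group on a different core, and its reading is a limit of the assay, not a number: the limit of < 12 mL.min-1.g-1 in this assay, at which 1 of the 3 values shown sits. Going by these compounds, whether a more different group at this position, such as an amine or a carboxylic acid, would move the number beyond the scatter remains open.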